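The source may hold more compounds than are shown below. What is called first, only, known or untested is meant among the compounds shown, and "the series" means these compounds.

Measured so far:
Compound 1 `O=C1Cc2cc(S(=O)(=O)N3CCNCC3)ccc2N1`: "not active" (no number reported)
Compound 2 `O=C1Cc2cc(S(=O)(=O)N3CCN(c4ccc([N+](=O)[O-])cc4)CC3)ccc2N1`: 3260 nM

Two compounds have been examined in an assay on isolated protein for inhibition of lysosomal alpha-glucosidase (Homo sapiens), read by fluorescence, with stated times of 5 min and 45 min; a higher number here means a weaker inhibitor, a lower number a stronger inhibitor. Compound 1 `O=C1Cc2cc(S(=O)(=O)N3CCNCC3)ccc2N1` is the unsubstituted piperazine, and in this assay compound 1 is reported as "not active" (no number reported), without a number. Compound 2 `O=C1Cc2cc(S(=O)(=O)N3CCN(c4ccc([N+](=O)[O-])cc4)CC3)ccc2N1` carries a 4-nitrophenyl on the piperazine nitrogen, and in this assay compound 2 gives 3260 nM. Compound 2 therefore holds the only number shown; the other entry is without a single number, so no step between measured compounds can be stated.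

Compound 3 `O=C1Cc2cc(S(=O)(=O)N3CCN(c4ccc(Br)cc4)CC3)ccc2N1` has not yet been measured. It differs from compound 2 in one place: bromo in place of nitro on an aromatic carbon. For the measured compounds named here, nothing among the measured compounds speaks to such an exchange, so the expectation rests on compound 2 alone. A step of modest size is expected, toward a weaker inhibitor or none beyond the scatter, and the expected step is a 1.4-fold higher number from compound 2 to compound 3 (0.14 log units; within the scatter). Compound 3 is accordingly estimated at 4500 nM, with a range from 1500 nM to 15000 nM.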

Compound 3, half-maximal inhibitory concentration: "not active" (no number reported)
The entry for compound 3 holds no number; there is nothing to compare the estimate with.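

In this assay, for the compounds shown here, compound 3 is reported as "not active" (no number reported) and so, with a number for compound 2 alone, no step between compound 2 and compound 3 can be read. No evidence shown bears on this result. The compounds shown leave open how any other group in place of the nitro would fare in this assay.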